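A few compounds are considered here, and "the series" means these few. Any claim that something is new, unique, unknown or untested is made for them only; others in the source may bear on it.

Measured so far:
- Compound 1 `Cn1nccc1-c1cnc(NCc2c(F)ccc3c2CCO3)c2cn[nH]c(=O)c12`; in a physicochemical assay for lipophilicity, using the shake flask method, in phosphate buffer, measured as octanol-water partition, with a stated time of 30 min, at pH 7.4 (a higher number here means a more lipophilic compound, a lower number a more polar compound), compound 1 gives 2.6
- Compound 2 `O=C1CC2(CC2)CN1c1cnc(NCc2c(F)ccc3c2CCO3)n2cnnc12`; in this assay compound 2 gives 1.9

Compound 2 has the lower of the two numbers, and compound 1 stands higher, beyond the usual scatter. Compound 3 `CN(C(=O)c1ccccc1)c1cnc(NCc2c(F)ccc3c2CCO3)n2cnnc12` has not yet been measured. It differs from compound 2 in one place: a group of 10 heavy atoms (8 carbon, 1 nitrogen, 1 oxygen; one six-membered aromatic ring of carbon only) in place of a group of 8 heavy atoms (6 carbon, 1 nitrogen, 1 oxygen; one three-membered non-aromatic ring of carbon only, one five-membered non-aromatic ring with 1 hetero atom), on an aromatic carbon. For the measured compounds named here, with no measured pair to lean on, the expectation rests on the change alone: a modest rise in lipophilicity is expected, as the step of a number 0.70 log units higher from compound 2 to compound 3 (beyond the scatter). Compound 3 is therefore estimated at 2.6, within a range from 2 to 3.2.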

Compound 3, distribution coefficient: 2.4
Compound 3: middle estimate off by 0.20 log units, on the high side; low and high end bracket the measured number.
By their numbers in this assay, from the lowest: compound 2; then compounds 3 and 1 (each within the scatter of the next).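

In this assay, benzoyl(methyl)amino entering in place of the group with the three-membered and five-membered rings gives a number 0.50 log units higher from compound 2 to compound 3 (beyond the scatter) on this aromatic carbon. The number therefore responds to a change of group here, even though both groups count the same hydrogen-bond donors and acceptors. Nothing measured here explains the size or direction of this step. Still open, on these data alone, is how a simple amine or a carboxylic acid on this carbon would read. As far as these compounds go, it is also open whether benzoyl(methyl)amino without its methyl would give a similar number.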